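From pyrimidin-2-yl to pyridin-2-yl on a sulfur

This account rests on a few compounds, and the source may have more. Where it says the series, first, only, none or still open, it means among the compounds named here.

Three compounds have been measured in a functional assay on NCI-H1975 cells (Homo sapiens) for inhibition, read by MTT assay, with a stated time of 72 h; a lower number here means a stronger inhibitor, a higher number a weaker inhibitor
compound 1 `FC(F)(F)c1ccc(CSc2nc(N3CCNCC3)cc(C(F)(F)F)n2)cc1` gives 6210 nM
compound 2 `CN1CCN(c2cc(C(F)(F)F)nc(SCc3ccc(C(F)(F)F)cc3)n2)CC1` gives 23900 nM
compound 3 `FC(F)(F)c1ccc(CSc2nc(Sc3ncccn3)cc(C(F)(F)F)n2)cc1` gives 14000 nM

Two steps show where compound 3 stands. Its number cannot be told apart from its nearest neighbour's (a 1.7-fold lower number from compound 2 to compound 3 (0.23 log units; within the scatter)), while its furthest neighbour is the strongest inhibitor of the set (a 2.3-fold higher number from compound 1 to compound 3 (0.35 log units; beyond the scatter)).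

Compound 4 `FC(F)(F)c1ccc(CSc2nc(Sc3ccccn3)cc(C(F)(F)F)n2)cc1` keeps the shared core and carries pyridin-2-yl in place of pyrimidin-2-yl on a sulfur so the swap amounts to one ring atom.

Within the data shown here, no measured pair makes this exact change. The closest evidence comes from the two steps above, which replace the whole piperazine-based group at this place with (pyrimidin-2-yl)sulfanyl. Even those much larger changes were modest or lay within the scatter. The remaining step, a methyl in place of hydrogen on the piperazine nitrogen, was also modest (a 3.8-fold higher number from compound 1 to compound 2 (0.59 log units; beyond the scatter)). A smaller edit should therefore move the number little, and the data give no firm direction. The step in this assay is expected to be small: the estimate is a 1.2-fold lower number from compound 3 to compound 4 (0.07 log units; within the scatter) and no change beyond the scatter is expected. For compound 4 the estimated value is 12000 nM with an expected range from 5500 nM to 26000 nM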

Compound 4, half-maximal inhibitory concentration: 23900 nM
For compound 4 the middle estimate is 2.0-fold (0.30 log units) below the measured one, within the range that was stated.
By their numbers in this assay, from the lowest: compound 1; then compounds 3, 2 and 4 (each within the scatter of the next).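

In this assay, removing one ring nitrogen from the group on the sulfur gives a step that cannot be told apart from scatter (a 1.7-fold higher number from compound 3 to compound 4 (0.23 log units; within the scatter)), so the pyrimidin-2-yl and pyridin-2-yl versions of this group read alike here. The new compound also shows that (pyridin-2-yl)sulfanyl and 4-methylpiperazin-1-yl cannot be separated at this place on the shared core (no change at the digits printed from compound 2 to compound 4 (within the scatter)), while piperazin-1-yl now stands apart from both sulfur-linked rings (a 3.8-fold higher number from compound 1 to compound 4 (0.59 log units; beyond the scatter)), which leaves compound 1 as the strongest inhibitor of the four, though only by a modest margin. Nothing among the data available accounts for these numbers.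

From the compounds shown here alone, whether the ring nitrogens matter at all remains open, as a phenyl ring on the same sulfur would be needed to test a ring with no nitrogen. It is also unclear whether the edge held by piperazin-1-yl extends to other groups at this place, such as morpholine or an open-chain amine.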